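Benzoyloxy in Place of Phenyl: an Expected Tolerance

The source may report more compounds than this note shows. Statements on the series, on what has been measured and on what is new or still open speak of the compounds shown alone.

Of the compounds shown here, two sharing one core have been measured in a functional assay on HEL cells (Homo sapiens); a lower number here means that less compound is tolerated, a higher number that more compound is tolerated. Compound 1 `O=C1c2ccccc2N(COCc2ccccc2)S(=O)(=O)N1Cc1ccccc1` gives 122000 nM in this assay, the lower of the two numbers recorded so far. Compound 2 `O=C1c2ccccc2N(COCc2ccccc2)S(=O)(=O)N1COCc1ccccc1` gives 200000 nM in this assay. Within the data shown here, the only measured step, a 1.6-fold higher number from compound 1 to compound 2 (0.21 log units; within the scatter), puts benzyloxy in place of phenyl on a saturated chain carbon bound to an amide-type nitrogen in a ring, and it stays within the scatter.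

Compound 3 `O=C(OCOCN1c2ccccc2C(=O)N(Cc2ccccc2)S1(=O)=O)c1ccccc1` has not yet been measured. Compared with compound 1 it carries benzoyloxy in place of phenyl on a saturated chain carbon bound to an oxygen on a saturated carbon. Among the measured compounds shown here, the single measured step is the only guide, and it is indirect: it exchanged a phenyl for a larger oxygen-containing group at a different place on the same core and produced a step of a 1.6-fold higher number from compound 1 to compound 2 (0.21 log units; within the scatter), within the scatter. Nothing measured points to a direction for the present exchange. The expectation is therefore a change no larger than the scatter, a 1.2-fold higher number from compound 1 to compound 3 (0.09 log units; within the scatter). On that basis compound 3 is estimated at 150000 nM in this assay, with a range from 70000 nM to 320000 nM.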

Compound 3, minimum cytotoxic concentration: 110000 nM
The estimate for compound 3 lay 1.4-fold (0.13 log units) above the measured number; the range from low to high includes it.
By their numbers in this assay, from the lowest: compounds 3, 1 and 2 (each within the scatter of the next).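

On the core of compound 1, the phenyl on a saturated chain carbon bound to an oxygen on a saturated carbon has now been exchanged for benzoyloxy, and in this assay this gives a 1.1-fold lower number from compound 1 to compound 3 (0.04 log units; within the scatter). Among these compounds, the only earlier step concerned a different place, a saturated chain carbon bound to an amide-type nitrogen in a ring, so this is the first reading for the present position: benzoyloxy, with 9 heavy atoms against the 6 of phenyl, 2 hydrogen-bond acceptors against 0, and a double bond outside aromatic rings, leaves the number within the scatter of the one for compound 1. Nothing available explains why this exchange leaves this assay so little changed.

On these data alone, with a single exchange at this position, it remains open whether an amine, a carboxylic acid or a longer chain there would also stay within the scatter. As far as these compounds go, it is also open whether benzoyloxy would give a similar reading on compound 2, which carries the change at the other place.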